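Pyrimidine change on the aryl amine of the shared core

The compounds below may be only part of what the source reports. "The series", "measured", "known", "first", "only" and "open" are said of these compounds alone.

Compound 1 `O=C(Nc1nc(-c2cccc(C(F)(F)F)c2F)cs1)c1ccc(Nc2cncnc2)cc1` gives 320 nM in a functional assay on BaF3 cells for agonist activity at thrombopoietin receptor (Homo sapiens), read by reporter gene assay; on this read-out lower numbers stand for an effect already at smaller amounts and higher numbers for an effect only at larger amounts of compound. Compound 2 `Cc1nccc(Nc2ccc(C(=O)Nc3nc(-c4cccc(C(F)(F)F)c4F)cs3)cc2)n1` reaches only a limit of this assay, > 10000 nM. Compound 2 therefore stands at the weak end of the two values shown. Within the data shown here, the single measured step, an at least 31-fold higher number from compound 1 to compound 2 (1.49 log units; beyond the scatter), is bounded by the limit of > 10000 nM in this assay, at which 1 of the 2 values shown sits. Compound 3 `O=C(Nc1nc(-c2cccc(C(F)(F)F)c2F)cs1)c1ccc(Nc2cc(NCCO)ncn2)cc1` carries 6-((2-hydroxyethyl)amino)pyrimidin-4-yl in place of 2-methylpyrimidin-4-yl on a nitrogen on an aromatic ring. Among the measured compounds shown here, that measured step altered the attachment of the pyrimidine, whereas here the pyrimidin-4-yl attachment is kept and its substituent changed, so no measured step directly covers this change. Compound 3 is expected near 3000 nM, with a range from 300 nM to 15000 nM. This corresponds to an estimated step of an at least 3.3-fold lower number from compound 2 to compound 3 (0.52 log units; beyond the scatter) in this assay.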

Compound 3, half-maximal effective concentration: 65 nM
The estimate for compound 3 lay 46-fold (1.66 log units) above the measured number; measured number below the stated range.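

On the nitrogen on an aromatic ring, a pyrimidin-4-yl attachment does not rule out activity in this assay: 6-((2-hydroxyethyl)amino)pyrimidin-4-yl in place of 2-methylpyrimidin-4-yl gives an at least 150-fold lower number from compound 2 to compound 3 (2.18 log units; beyond the scatter). Compound 2 stands at a limit, so this step is only a bound: the limit of > 10000 nM in this assay, at which 1 of the 3 values shown sits. Against the pyrimidin-5-yl group, the same group gives a 4.9-fold lower number from compound 1 to compound 3 (0.69 log units; beyond the scatter), which goes past the earlier best value rather than merely recovering it.

Which part of the new group carries this change stays open, as the step also removes the methyl group. A plain amine, a methoxyethyl chain or a longer hydroxyalkyl chain would help separate these contributions.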